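Replacing 4-acetylphenyl with 3-methoxyphenyl in compound 3

A few compounds are considered here, and "the series" means these few. Any claim that something is new, unique, unknown or untested is made for them only; others in the source may bear on it.

Values measured in a functional assay on DU-145 cells (Homo sapiens) for cytotoxicity, read by MTT assay, with a stated time of 48 h (a lower number here means a stronger inhibitor, a higher number a weaker inhibitor), are:

Compound 1 `C=C1CCC[C@]2(C)CCC(C=O)=CC[C@@]12C` gives 152000 nM
Compound 2 `C#CC1=CC[C@]2(CC1)C(=C)CC[C@H]2C(C)C` gives 121000 nM
Compound 3 `C=C1CCC[C@]2(C)CCC(c3cn(-c4ccc(C(C)=O)cc4)nn3)=CC[C@@]12C` gives 51700 nM

Compound 3 has the lowest number of the three, and its gaps to compound 1 and compound 2 lie beyond the scatter. Compound 4 `C=C1CCC[C@]2(C)CCC(c3cn(-c4cccc(OC)c4)nn3)=CC[C@@]12C`, not yet measured, carries 3-methoxyphenyl in place of 4-acetylphenyl on an aromatic nitrogen in comparison with compound 3. For the measured compounds named here, no measured pair shows a change at this place, so in this assay no step beyond the scatter is expected in either direction. The estimate amounts to an expected step of a 1.2-fold higher number from compound 3 to compound 4 (0.06 log units; within the scatter) and stays within the scatter. Compound 4 is expected at 60000 nM (estimated range 30000 nM to 120000 nM).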

Compound 4, half-maximal inhibitory concentration: 38900 nM
The estimate for compound 4 lay 1.5-fold (0.19 log units) above the measured number; the measured number falls inside the stated range.
By their numbers in this assay, from the lowest: compounds 4 and 3 (each within the scatter of the next); then compounds 2 and 1 (each within the scatter of the next).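

Exchanging 4-acetylphenyl for 3-methoxyphenyl on the aromatic nitrogen gives a 1.3-fold lower number from compound 3 to compound 4 (0.12 log units; within the scatter) in this assay. This first pair differing at this place shows that the two aryl groups, which differ in both their substituent and its ring position, cannot be told apart in this read-out. No available evidence explains this result. The compounds shown leave open whether a substituent on this phenyl ring matters at all, and how an amine or a carboxylic acid in its place would read.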